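Swapping a ring-nitrogen methyl for hydrogen in compound 1

This account rests on a few compounds, and the source may have more. Where it says the series, first, only, none or still open, it means among the compounds named here.

For the measured compounds named here, in a functional assay on L1210 cells (Mus musculus) for inhibition, read by cell counting, with a stated time of 48 h (a higher number here means a weaker inhibitor, a lower number a stronger inhibitor), compound 1 (`COc1ccc(N(C)c2nc(C)nc3c2nc(C)n3C)cc1`) gives 19000 nM as one of only two exact numbers in the set. Compound 3 (`COc1ccc(N(C)c2nc(C)nc3c2ncn3C)cc1`) gives 30000 nM as the other, and the gap between them is a 1.6-fold higher number from compound 1 to compound 3 (0.20 log units; within the scatter) with hydrogen in place of methyl on an aromatic carbon. Compound 2 (`COc1ccc(Nc2nc(C)nc3c2nc(C)n3C)cc1`) returns >= 250000 nM which is a limit. Its step, an at least 13-fold higher number from compound 1 to compound 2 (1.11 log units; beyond the scatter), puts hydrogen in place of methyl on a nitrogen on an aromatic ring.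

Compound 4 (`COc1ccc(N(C)c2nc(C)nc3[nH]c(C)nc23)cc1`) carries the change (hydrogen in place of methyl on an aromatic nitrogen), which is hydrogen in place of methyl on an aromatic nitrogen of a five-membered aromatic ring. Neither measured step falls at this place. Compound 2 is the closer guide as the other loss of a methyl from a nitrogen, while compound 3 shows that a methyl loss can also pass within the scatter. The expected step is a 2.9-fold higher number from compound 1 to compound 4 (0.46 log units; beyond the scatter) in this assay and points to a weaker inhibitor, with wide uncertainty. Compound 4 is estimated at 55000 nM with a range of 15000 nM to 200000 nM as the expected bounds.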

Compound 4, half-maximal inhibitory concentration: 229000 nM
Compound 4: middle estimate off by 4.2-fold (0.62 log units), on the low side; the whole stated range lies below it.
By their numbers in this assay, from the lowest: compounds 1 and 3 (each within the scatter of the next); then compound 4. At a limit, above all of these: compound 2.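

In this assay, the methyl on the aromatic nitrogen of the five-membered aromatic ring proves far from dispensable, with hydrogen in its place giving a 12-fold higher number from compound 1 to compound 4 (1.08 log units; beyond the scatter). This sets the position apart from the aromatic carbon, where the same exchange of methyl for hydrogen gives a 1.6-fold higher number from compound 1 to compound 3 (0.20 log units; within the scatter), so in this set the effect of removing a methyl depends on where it sits. Compound 4 also joins compound 2 as a second case of a large step on losing a methyl from a nitrogen, although the step to compound 2 rests on a limit: the limit of >= 250000 nM in this assay, at which 1 of the 4 values shown sits.

The compounds shown leave open whether an ethyl group, a longer chain or a chain ending in a carboxylic acid on this ring nitrogen would keep the number of compound 1. They also leave open whether the step would hold in a compound that lacks the methyl on the aromatic carbon as well.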